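Series notes: pentyl in place of ethoxycarbonyl

The source may report more compounds than this note shows. Statements on the series, on what has been measured and on what is new or still open speak of the compounds shown alone.

Measured so far in a functional assay on WI-38 VA13 cells (Homo sapiens) for cytotoxicity; a lower number here means that less compound is needed, a higher number that more compound is needed for the effect:
compound 1 `N#Cc1ccc(C(=O)Nc2ccc3nc(NC(=O)C4CCCCC4)sc3c2)cc1`, 3.3 ug/mL
compound 2 `CCCCOc1ccc(S(=O)(=O)Nc2ccc3nc(NC(=O)C4CCCCC4)sc3c2)cc1`, 0.75 ug/mL
compound 3 `CCOC(=O)Nc1nc2ccc(NC(=O)c3c(Cl)cccc3Cl)cc2s1`, 0.0026 ug/mL

Compound 3 stands at the lowest of the three numbers in this assay, and its distance to compound 2, the nearest of the other two, lies beyond the scatter, as does its larger distance to compound 1. Going by the values given here, compounds 1 and 2 share a cyclohexanecarbonyl amide on the core, whereas compound 3 carries an ethoxycarbonyl there and a different amide on the other side, so the three values show no single-point comparison and no step between measured compounds can be given.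

Among the compounds with values here, compound 4 `CCCCCNc1nc2ccc(NC(=O)c3c(Cl)cccc3Cl)cc2s1` is the first single-point change in the set. Compared with compound 3 it differs as follows: pentyl in place of ethoxycarbonyl on a nitrogen on an aromatic ring. Within the data shown here, no measured compound carries a plain alkyl on that nitrogen, so the expectation rests on compound 3 alone, with its value of 0.0026 ug/mL as the only anchor. The step from compound 3 to compound 4 is expected to go toward a higher number in this assay, by a 12-fold higher number from compound 3 to compound 4 (1.06 log units; beyond the scatter), beyond the scatter. Compound 4 is accordingly estimated at 0.03 ug/mL, in a range from 0.004 ug/mL to 0.3 ug/mL.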

Compound 4, half-maximal effective concentration: 0.27 ug/mL
Estimate against measurement, compound 4: 9.0-fold (0.95 log units) below; measured number inside the range.
By their numbers in this assay, from the lowest: compound 3; then compound 4; then compound 2; then compound 1.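

Going by these compounds alone, on the nitrogen on an aromatic ring, pentyl in place of ethoxycarbonyl gives the first single-point reading of the series: in this assay the number moves by a 100-fold higher number from compound 3 to compound 4 (2.02 log units; beyond the scatter), so this position is not indifferent to the group it carries. Ethoxycarbonyl and pentyl hold the same number of heavy atoms and neither has a ring, so the step arises with the heavy-atom count unchanged, while the carbonyl double bond, the oxygens and the hydrogen-bond acceptors of the leaving group are all gone from the entering one. No measurement here bears on what lies behind the step.

One exchange cannot separate the contribution of the carbonyl from that of the ester oxygen or the alkyl chain, a question that an acetyl, a butyl or a hexyl chain on the same nitrogen, or a chain ending in an amine or a carboxylic acid, would bear on. On these data alone, whether the step holds with a cyclohexanecarbonyl amide in place of the amide on the other side of the shared core also remains open.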